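Removing a Chloro Group on the Pyridine of Compound 3

This account rests on a few compounds, and the source may have more. Where it says the series, first, only, none or still open, it means among the compounds named here.

Compound 1 `Cn1nc(C(=O)O)c2ccc(N3C(=O)CCc4cc(OCc5c(-c6c(Cl)cccc6Cl)noc5C5CC5)ccc43)cc21` gives > 100% in an assay on isolated protein for agonist activity at Bile acid receptor (Homo sapiens), read by AlphaScreen, with a stated time of 1 h (on this read-out higher numbers stand for larger maximal responses and lower numbers for smaller maximal responses), a limit of this assay rather than a number.
Compound 2 `O=C1CCc2cc(OCc3c(-c4c(Cl)cccc4Cl)noc3C3CC3)ccc2N1c1ncc(O)cc1F` gives > 100% in this assay, again a limit.
Compound 3 `O=C(O)c1cnc(N2C(=O)CCc3cc(OCc4c(-c5c(Cl)cccc5Cl)noc4C4CC4)ccc32)c(Cl)c1` gives > 100% in this assay, also a limit.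

Compound 3 thus stands at the same limit as the two others: the limit of > 100% in this assay, at which 3 of the 3 values shown sit. Among the measured compounds shown here, the only measured step between neighbours, a step that the two limits leave unreadable from compound 2 to compound 3, cannot be read for size, since both ends are limits.

Compound 4 `O=C(O)c1ccc(N2C(=O)CCc3cc(OCc4c(-c5c(Cl)cccc5Cl)noc4C4CC4)ccc32)nc1` is compound 3 with one change: hydrogen in place of chloro on an aromatic carbon. For the measured compounds named here, no measured step touches this particular change, and the one step that exists gives no readable size, so the expectation rests on the limit alone. Compound 4 is expected to reach about 100% in this assay, with a range from 80% to 120%, most likely reported as a limit. The expected step from compound 3 to compound 4 is a number no higher from compound 3 to compound 4 (the limit leaves the size open), that is, none beyond the scatter.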

Compound 4, largest response reached (Emax), in percent of the reference or control that the assay uses: > 100%
Compound 4: only a limit was reported; the forecaster's own chance of this, stated with the estimate: 70%; the middle value sits exactly at the limit.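

Compound 4 gives > 100% in this assay, again a limit and not a number. The steps from compound 2 and compound 3 to compound 4 therefore cannot be read for size. The compounds shown leave open whether hydrogen in place of chloro changes the maximal response at all.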